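The source may hold more compounds than are shown below. What is called first, only, known or untested is meant among the compounds shown, and "the series" means these compounds.

Three compounds have been examined in a functional assay on the whole organism for inhibition, with Rattus norvegicus as the target, at a dose of 30 mg/kg; a lower number here means less inhibition, a higher number more inhibition at the dose given (going by the name of the read-out). Compound 1 `c1ccc(-c2nc3cccnc3o2)cc1` carries an unsubstituted phenyl ring on its core, and in this assay compound 1 gives 55%. Compound 3 `Cc1cccc(-c2nc3cccnc3o2)c1` shares that core but bears a methyl on the phenyl ring, and in this assay compound 3 gives 14%. The two differ in one place, (hydrogen in place of methyl on an aromatic carbon), meta to a group of 9 heavy atoms, and the step of a number 41 percentage points higher from compound 3 to compound 1 (beyond the scatter) is a large one. Compound 2 `Cc1ccccc1-c1nc2ncccc2o1` has the same atoms as compound 3 joined differently; the difference between the two cores is not broken down here. In this assay compound 2 gives 0%, the lowest of the three numbers.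

Compound 4 `c1ccc(-c2nc3ncccc3o2)cc1` has not yet been measured. It differs from compound 2 by hydrogen in place of methyl on an aromatic carbon, ortho to a group of 9 heavy atoms. Going by the values given here, this is the same kind of change as the one from compound 3 to compound 1, not the same change: in compound 2 the methyl leaves from a position ortho to the group of 9 heavy atoms rather than meta, and the core is the other one. Because a number 41 percentage points higher from compound 3 to compound 1 (beyond the scatter) was large, the step of a number 35 percentage points higher from compound 2 to compound 4 (beyond the scatter) is expected, with the different core and the different place of the methyl leaving its size uncertain. Compound 4 is therefore expected to give about 35%, most likely between 10% and 60%.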

Compound 4, a percentage reported as inhibition, in the whole organism at one dose (the size of the read-out at that dose, not a potency): 41%
The estimate for compound 4 lay 6 percentage points below the measured number; the measured number falls inside the stated range.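

In this assay, hydrogen in place of methyl on an aromatic carbon gives a number 41 percentage points higher from compound 2 to compound 4 (beyond the scatter), and this step can be set directly beside the earlier one on the other core: the same change on two cores in this assay, a number 41 percentage points higher (beyond the scatter) from compound 3 to compound 1 and a number 41 percentage points higher (beyond the scatter) from compound 2 to compound 4, 0 percentage points apart, within the scatter of two such steps

Across these two pairs, then, removing the methyl from the phenyl ring carries over from one core to the other with no measurable difference in size, even though the methyl leaves from a different place on the ring in each pair. Going by these compounds alone, this does not show that the step would keep its size on a third core, and with only two pairs, the core and the place of the methyl change together, so their separate contributions cannot be told apart, nor does it explain why the methyl-bearing compounds give the lower numbers.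

The compounds shown leave open how groups other than methyl, such as a methoxy group, a chlorine atom, an amine or a carboxylic acid, would behave on the phenyl ring of either core. They also leave open how these numbers would change at other doses, as each read-out comes from a single dose and is not a potency.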